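Replacing a chlorinated ester-bearing ring with a methylated one

This account rests on a few compounds, and the source may have more. Where it says the series, first, only, none or still open, it means among the compounds named here.

Compound 2 `COC(=O)c1cc(Cl)ccc1OC(=O)COc1cc(O)c2c(=O)cc(-c3ccccc3)oc2c1` carries a 4-chloro-2-(methoxycarbonyl)phenyl group on an oxygen next to a carbonyl group. Among the measured compounds shown here, in a functional assay on cells (T-cell, Mus musculus, strain BALB/c) for inhibition, read by MTT assay, with a stated time of 72 h (a higher number here means a weaker inhibitor, a lower number a stronger inhibitor), compound 2 gives 3740 nM, the lowest of the two numbers measured so far. For the measured compounds named here, its only neighbour is compound 1 `COC(=O)c1c(F)cccc1OC(=O)COc1cc(O)c2c(=O)cc(-c3ccccc3)oc2c1`, which bears a 3-fluoro-2-(methoxycarbonyl)phenyl group in the same place and gives 40300 nM in this assay; the step of an 11-fold lower number from compound 1 to compound 2 (1.03 log units; beyond the scatter) shows that changing this ring can shift the read-out strongly.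

Compound 3 `COC(=O)c1ccc(C)cc1OC(=O)COc1cc(O)c2c(=O)cc(-c3ccccc3)oc2c1` is not yet measured. It differs from compound 2 in one place: a group of 11 heavy atoms (9 carbon, 2 oxygen; one six-membered aromatic ring of carbon only) in place of a group of 11 heavy atoms (8 carbon, 2 oxygen, 1 chlorine; one six-membered aromatic ring of carbon only), on an oxygen next to a carbonyl group. Going by the values given here, the only relevant comparison is the step from compound 1 to compound 2, which was large, but it involved a different pair of substituents, so it gives the direction of possible change rather than a firm guide. The methyl-bearing ring is expected to land somewhere between the two measured values, most likely a modest weakening relative to compound 2, estimated as a 1.9-fold higher number from compound 2 to compound 3 (0.27 log units; within the scatter). Compound 3 is therefore expected to give about 7000 nM in this assay, within a range from 1500 nM to 30000 nM.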

Compound 3, half-maximal inhibitory concentration: 31100 nM
Beside the measured number, compound 3's estimate is 4.4-fold (0.65 log units) below it, and the stated range ends below it.
By their numbers in this assay, from the lowest: compound 2; then compounds 3 and 1 (each within the scatter of the next).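

Exchanging the 4-chloro-2-(methoxycarbonyl)phenyl group for the methyl-bearing ring, with the same count of heavy atoms, leaves the ester and the shared core untouched, yet in this assay it gives an 8.3-fold higher number from compound 2 to compound 3 (0.92 log units; beyond the scatter). So a change this small on the ring can undo almost all of the advantage that compound 2 holds, and that advantage is not a general feature of rings carrying a methoxycarbonyl group. The comparison with the fluorinated ring, a 1.3-fold lower number from compound 1 to compound 3 (0.11 log units; within the scatter), does not separate those two rings, which leaves compound 2 as the only one of the three that stands apart, as the strongest inhibitor here, and nothing available explains why its chlorinated ring does so.

As far as these compounds go, whether the lower number follows the chlorine atom itself or some other feature of that particular ring remains open, and a bromine atom, a methoxy group or a nitrile on the ring would help to tell these apart. Also open, from the compounds shown here alone, is whether the methyl ester matters at all, which a carboxylic acid or an amide in its place could test.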